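The source may report more compounds than this note shows. Statements on the series, on what has been measured and on what is new or still open speak of the compounds shown alone.

In a functional assay on GBM1 cells (Homo sapiens) for antiproliferative activity, read by WST assay, with a stated time of 72 h (a lower number here means a stronger inhibitor, a higher number a weaker inhibitor), compound 1 `O=C(Nc1ccc(C(F)(F)F)cc1)Nc1cc2ncncc2cc1OCc1cccc(F)c1` gives 3800 nM. Compound 2 `O=C(Nc1ccc(Cl)c(Cl)c1)Nc1cc2ncncc2cc1OCc1cccc(F)c1` gives 2100 nM, and compound 3 `O=C(Nc1cccc(F)c1)Nc1cc2ncncc2cc1OCc1ccccc1Cl` gives 4000 nM. Compound 1 lies within the scatter of both, so these numbers do not set it apart from either one.

Compound 4 `O=C(Nc1ccc(C(F)(F)F)cc1)Nc1cc2ncncc2cc1OCc1ccccc1` is compound 1 with a single small edit: hydrogen in place of fluoro on an aromatic carbon. Hydrogen stands in place of fluoro on an aromatic carbon, which turns the 3-fluorobenzyl into benzyl.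

For the measured compounds named here, only one measured step bears on this, and only indirectly. The step of a 1.8-fold lower number from compound 1 to compound 2 (0.26 log units; within the scatter) lies within the scatter, and it changes a different part of the molecule, the 4-(trifluoromethyl)phenyl on an amide-type nitrogen. Compound 3 differs from compound 1 in more than one place, so it isolates no single change. Going by the values given here, no measured pair shows this fluoro being removed, so the data suggest no direction, and no step beyond the scatter is expected in this assay. For compound 4 the estimated value is 4000 nM, with an expected range of 1700 nM to 9000 nM. This estimate means an expected 1.1-fold higher number from compound 1 to compound 4 (0.02 log units; within the scatter).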

Compound 4, half-maximal inhibitory concentration: 5700 nM
Compound 4: middle estimate off by 1.4-fold (0.15 log units), on the low side; the measured number falls inside the stated range.
By their numbers in this assay, from the lowest: compounds 2, 1, 3 and 4 (each within the scatter of the next, the first and the last beyond it).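

In this assay, for the compounds shown here, taking the fluoro off the benzyl group gives a 1.5-fold higher number from compound 1 to compound 4 (0.18 log units; within the scatter) and this is the first pair of compounds that isolates this position. With the 4-(trifluoromethyl)phenyl and the shared core unchanged, going from 3-fluorobenzyl to benzyl does not separate compound 4 from compound 1, so this pair gives no sign that the fluoro matters in this assay. No measured evidence is available to explain the result.

Going by these compounds, it remains open whether a different group on this aromatic carbon, such as a methoxy group, an amine or a carboxylic acid, would produce a step beyond the scatter. On these data alone, it is also open whether removing this fluoro would give a similar result in compound 2, which carries a 3,4-dichlorophenyl instead.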